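Dimethylamino versus pyrrolidinyl on the aniline of a kinase series

This account rests on a few compounds, and the source may have more. Where it says the series, first, only, none or still open, it means among the compounds named here.

Compounds measured so far:
compound 1 `CCCN(CCC)c1ccc(Nc2ncc(Cl)c(Oc3cccc(NC(=O)CC)c3)n2)cc1`: 9.3%
compound 2 `CCC(=O)Nc1cccc(Oc2nc(Nc3ccc(N(C)C)cc3OC)ncc2Cl)c1`: 80.6%
compound 3 `CCC(=O)Nc1cccc(Oc2nc(Nc3ccc(N4CCCC4)cc3)ncc2Cl)c1`: "not active" (no number reported)

Three compounds share one core and differ in the substitution of the aniline ring. In an assay on isolated protein for inhibition of NUAK family SNF1-like kinase 1 (Homo sapiens), read by ADP-Glo, with a stated time of 60 min, tested at 10 uM, in the presence of a further agent that is not named here (a higher number here means more inhibition at the concentration tested (going by the name of the read-out), a lower number less inhibition), compound 1 gives 9.3%. In this assay compound 2 gives 80.6%. Compound 3 is reported in this assay only as "not active" (no number reported), with no number attached, so it cannot be placed on the same scale as compound 1 or compound 2; all that can be said is that compound 3 is reported as not active.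

Compound 4 `CCC(=O)Nc1cccc(Oc2nc(Nc3ccc(N(C)C)cc3)ncc2Cl)c1` has not yet been measured. It differs from compound 3 in a single place: dimethylamino in place of pyrrolidin-1-yl on an aromatic carbon. Within the data shown here, no measured pair tracks exactly this exchange, so no step between known values can be quoted for it. Compound 2 carries the same dimethylamino group, together with a further methoxy substituent, and compound 1 carries a larger dialkylamino group, so the two anchor points for the expectation lie far apart. Compound 4 is expected to give an inhibition in this assay of about 40%, with a plausible range from 10% to 80%.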

Compound 4, a percentage reported as inhibition, at one concentration (the size of the read-out at that concentration, not a potency): 72.6%
Compound 4: the middle estimate sits 32.6 percentage points below what was measured; measured number inside the range.
By their numbers in this assay, from the lowest: compound 1; then compounds 4 and 2 (each within the scatter of the next).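

In this assay, the step (a number 8 percentage points lower from compound 2 to compound 4 (within the scatter)) shows that the methoxy group is not needed for the inhibition seen with the dimethylamino aniline, since hydrogen in its place leaves the read-out within the scatter. The change at the amine is a different matter: dimethylamino in place of dipropylamino gives a large step (a number 63.3 percentage points higher from compound 1 to compound 4 (beyond the scatter)), so the size of the alkyl groups on this nitrogen, on an aromatic carbon para to a large group, goes with a clear difference in the read-out. Compound 4 also gives a number (72.6%) where compound 3, with pyrrolidin-1-yl at the same place, is reported only as not active, so that exchange separates the two compounds, although the size of the step cannot be read. Nothing given here explains these differences.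

The compounds shown leave open whether diethylamino, which lies between dimethylamino and dipropylamino in chain length, or a six-membered ring amine such as piperidine or morpholine would keep the inhibition. They also leave open whether a smaller methylamino group or a free amine would serve at this place, and how potent compound 4 is, as the read-out comes from one concentration only.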